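A few compounds are considered here, and "the series" means these few. Any claim that something is new, unique, unknown or untested is made for them only; others in the source may bear on it.

Compound 1 `CNc1nc(NCCCN(C)C)c2sc(-c3ccc(S(C)(=O)=O)cc3)cc2n1` gives 2.1 in a physicochemical assay for lipophilicity, read by HPLC, at pH 7.4; on this read-out higher numbers stand for higher lipophilicity and lower numbers for lower lipophilicity. Compound 2 `CNc1nc(NCCCN(C)C)c2sc(-c3cccc(C#N)c3)cc2n1` gives 2.9. Compound 3 `CNc1nc(NCCCN(C)C)c2sc(-c3ccc(OC)nc3)cc2n1` gives 2.8.

Among these three numbers compound 1 stands lowest, beyond the scatter from both compound 2 and compound 3. Compound 4 `CNc1nc(NCCCN(C)C)c2sc(-c3ccc(N4CCNCC4)cc3)cc2n1` arises from compound 1 by one change: piperazin-1-yl in place of methylsulfonyl on an aromatic carbon. Within the data shown here, the only measured step, a number 0.10 log units lower from compound 2 to compound 3 (within the scatter), swaps one aromatic ring for another and is within the scatter, so it says little about exchanging a substituent on the carbon ring that compound 1 and compound 4 share. Among the measured compounds shown here, no measured step anchors this change, and the expectation rests on compound 1 alone. Compound 4 is expected to give about 1.8 in this assay, between 1 and 2.6, an estimated step of a number 0.30 log units lower from compound 1 to compound 4 (within the scatter).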

Compound 4, distribution coefficient: 3.5
Compound 4: middle estimate off by 1.70 log units, on the low side, and the stated range ends below it.
By their numbers in this assay, from the lowest: compound 1; then compounds 3 and 2 (each within the scatter of the next); then compound 4.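

The position on the six-membered aromatic ring of carbon only, para to a large group, proves sensitive in this assay: the step with piperazin-1-yl in place of methylsulfonyl is a number 1.40 log units higher from compound 1 to compound 4 (beyond the scatter). The earlier compounds shown here offered only an exchange of one aromatic ring for another, which stayed within the scatter, so they gave no sign that a change here could move the number this far. Nothing at hand explains why this step is so large.

With one pair, the compounds shown leave open whether a morpholine or a 4-methylpiperazine at this position would give a number near that of compound 4. They also leave open whether the same exchange would give a similar step on a pyridine ring.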